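The source may report more compounds than this note shows. Statements on the series, on what has been measured and on what is new or still open speak of the compounds shown alone.

Compound 1 `COc1cc(/C=C/C(=O)c2ccc3ccccc3c2)cc(Br)c1OC` gives 2300 nM
Compound 2 `COc1cc(/C=C/C(=O)c2ccc3ccccc3c2)cc(I)c1OC` gives 1300 nM

Both values come from a functional assay on MCF7/Topo cells (Homo sapiens) for inhibition, read by MTT assay, with a stated time of 72 h (a higher number here means a weaker inhibitor, a lower number a stronger inhibitor), and are the only ones so far. Among the compounds with values here, compound 2 at 1300 nM has compound 1 as its sole neighbour, and the two lie within the scatter of each other, so neither ranks ahead. Compound 3 `COc1cc(/C=C/C(=O)c2ccc3ccccc3c2)cc(OC)c1OC` follows from compound 2 by methoxy in place of iodo on an aromatic carbon with methoxy in place of iodo on an aromatic carbon. Within the data shown here, the data hold no measured comparison with a methoxy group, and the one measured step exchanges one halogen for another. Among the measured compounds shown here, with a 1.8-fold lower number from compound 1 to compound 2 (0.25 log units; within the scatter) as the only guide, no change beyond the scatter is expected in this assay for compound 3, with a slight lean towards a higher number. The estimate below means an expected 1.5-fold higher number from compound 2 to compound 3 (0.19 log units; within the scatter) in this assay. Compound 3 is estimated at 2000 nM with a range from 600 nM to 7000 nM for its value.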

Compound 3, half-maximal inhibitory concentration: 5600 nM
Compound 3: the middle estimate sits 2.8-fold (0.45 log units) below what was measured; the measured number falls inside the stated range.
By their numbers in this assay, from the lowest: compounds 2 and 1 (each within the scatter of the next); then compound 3.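

In this assay this position now shows a change beyond the scatter: methoxy in place of iodo gives a 4.3-fold higher number from compound 2 to compound 3 (0.63 log units; beyond the scatter), and methoxy in place of bromo gives a 2.4-fold higher number from compound 1 to compound 3 (0.39 log units; beyond the scatter). The exchange of one halogen for the other stayed within the scatter, whereas both modest steps away from a halogen end at a higher number, so the position distinguishes methoxy from these two halogens, though not bromo from iodo. No available evidence bears on the reason for this difference.

The compounds shown leave open whether chloro, fluoro or a hydrogen at this position would read with the halogens or with compound 3. They also leave open how a hydroxy group, an amine or a longer ether chain such as ethoxy would read here.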